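The source may hold more compounds than are shown below. What is called first, only, known or untested is meant among the compounds shown, and "the series" means these compounds.

For the measured compounds named here, compound 1 (`Cc1ccc(C(Nc2ccc(C(=O)O)cc2)c2ccc3cccnc3c2O)cc1`) is the only compound in this set that comes with a number. In an assay on isolated protein for inhibition of CAAX prenyl protease 2 (Homo sapiens), with stated times of 60 s and 60 min (a lower number here means a stronger inhibitor, a higher number a weaker inhibitor), compound 1 gives 7100 nM, a rather high figure, which places it among the weaker inhibitors by the standard of this read-out. Compound 2 (`CCOC(=O)c1ccc(NC(c2ccc(F)cc2)c2ccc3cccnc3c2O)cc1`) was tested in the same setting, but for compound 2 the result in this assay is "not determined" (no result reported), so it offers no number to compare against. Going by the values given here, with only one measured value, there is no step between measured compounds to lean on.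

The next compound, compound 3 (`O=C(O)c1ccc(NC(c2ccccn2)c2ccc3cccnc3c2O)cc1`), keeps the shared core of compound 1 and changes one group: pyridin-2-yl in place of 4-methylphenyl on a saturated chain carbon bound to an aromatic carbon and a nitrogen on an aromatic ring. The change is small in size and swaps one six-membered aromatic ring for another of nearly the same shape. Without any measured step of this kind in the set, the expected change is modest, with no clear direction beyond the usual scatter, and the step from compound 1 to compound 3 is estimated at a 1.2-fold higher number from compound 1 to compound 3 (0.08 log units; within the scatter). Compound 3 is therefore expected to give about 8500 nM, within a range from 2800 nM to 26000 nM.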

Compound 3, half-maximal inhibitory concentration: 38000 nM
Estimate against measurement, compound 3: 4.5-fold (0.65 log units) below; measured number outside the range, above it.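

Placing pyridin-2-yl in place of 4-methylphenyl on a saturated chain carbon bound to an aromatic carbon and a nitrogen on an aromatic ring gives, in this assay, a 5.4-fold higher number from compound 1 to compound 3 (0.73 log units; beyond the scatter). This shows what compound 1 alone could not: the position is sensitive to which six-membered aromatic ring it carries, even though the two groups are close in heavy-atom count, and here the ring with one nitrogen and one hydrogen-bond acceptor goes with the weaker inhibitor. Nothing in the data shown explains why the number rises with this swap.

This single step cannot separate the loss of the methyl group from the entry of the ring nitrogen, and a plain phenyl group on the same carbon would be needed to tell those two changes apart. The compounds shown also leave open how pyridin-4-yl, or a ring carrying a methoxy group or an amine, would behave at this position.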